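The compounds below may be only part of what the source reports. "The series", "measured", "known", "first", "only" and "open" are said of these compounds alone.

Measured compounds:
compound 1, `COc1cc(C(c2ccc(O)c(OC)c2)[C@H](CF)C(C)C)ccc1O`: 19000 nM
compound 2, `COC[C@@H](C(C)C)C(c1ccc(O)c(OC)c1)c1ccc(O)c(OC)c1`: 69000 nM
compound 3, `COc1ccc(C(c2ccc(OC)c(OC)c2)[C@@H](C)[C@@H](C)CO)cc1OC`: a limit of the assay, > 100000 nM

These three share a core in which a saturated chain carbon is bound to two aromatic carbons and carries a branched side chain. In a functional assay on HeLa cells (Homo sapiens) for cytotoxicity, read by WST assay, with a stated time of 48 h (a higher number here means a weaker inhibitor, a lower number a stronger inhibitor), compound 1 gives 19000 nM and compound 2 gives 69000 nM. Compound 2 thus holds the highest of the two numbers, and its nearest neighbour is compound 1, as told by a 3.6-fold higher number from compound 1 to compound 2 (0.56 log units; beyond the scatter). Compound 3 reaches only a limit, > 100000 nM; it sits at the limit of > 100000 nM in this assay, at which 1 of the 3 values shown sits.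

Compound 4, `COc1cc(C(c2ccc(O)c(OC)c2)[C@H](CO)C(C)C)ccc1O`, is not yet measured. It differs from compound 2 in one place: 1-(hydroxymethyl)-2-methylpropyl in place of 1-(methoxymethyl)-2-methylpropyl on a saturated chain carbon bound to two aromatic carbons. Among the measured compounds shown here, the only measured step that touches this side chain is a 3.6-fold higher number from compound 1 to compound 2 (0.56 log units; beyond the scatter), in which a fluoromethyl gave way to the methoxymethyl. For the measured compounds named here, no measured step exchanges the methoxymethyl for a hydroxymethyl, so the direction of the new step is open. Compound 3 also carries a hydroxymethyl, on a different chain, and its value is only a limit. Given the modest size of the one step seen, the expected change is small, estimated as a 1.4-fold lower number from compound 2 to compound 4 (0.14 log units; within the scatter). Compound 4 is therefore estimated at 50000 nM, within 20000 nM to 150000 nM.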

Compound 4, half-maximal inhibitory concentration: > 100000 nM
Compound 4 ended at the assay's limit (the forecaster's own chance of this, stated with the estimate: 25%); middle value at least 2.0-fold (0.30 log units) from the limit.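

In this assay compound 4 gives no number of its own, only a limit of the assay: the limit of > 100000 nM in this assay, at which 2 of the 4 values shown sit. Set against the fluoromethyl side chain, the change is clear, with an at least 5.2-fold higher number from compound 1 to compound 4 (0.72 log units; beyond the scatter), so compound 1 now stands apart from both oxygen-bearing side chains and holds the lowest number of the three compounds that differ only in this group, since its step to compound 2 is also beyond the scatter. Set against the methoxymethyl side chain, the reading is much less firm, with an at least 1.4-fold higher number from compound 2 to compound 4 (0.16 log units; that floor lies within the scatter), so this floor alone does not separate the two compounds, and removing the methyl from the ether oxygen has no measured size.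

Going by these compounds, how far compound 4 lies past its limit stays open, and with it whether the hydroxymethyl side chain truly differs from the methoxymethyl one in this assay. On these data alone, it is also open whether an aminomethyl, a chloromethyl or a plain ethyl group in this place, on a saturated chain carbon bound to two aromatic carbons, would match compound 1 or give a lower number still.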